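Phenethyl in place of 4-bromophenyl on the thioether sulfur

The compounds below may be only part of what the source reports. "The series", "measured", "known", "first", "only" and "open" are said of these compounds alone.

In a functional assay on HeLa cells (Homo sapiens) for inhibition, read by CCK-8 assay, with a stated time of 72 h, tested at 2 uM (a lower number here means less inhibition of growth, a higher number more inhibition of growth at the concentration tested), compound 1 (`CCc1ccc(SCc2ccc(C(=O)Nc3ccccc3N)cc2)cc1`) gives 30.8% and compound 2 (`Cc1ccc(SCc2ccc(C(=O)Nc3ccccc3N)cc2)cc1`) gives 33.8% while compound 3 (`Nc1ccccc1NC(=O)c1ccc(CSc2ccc(Br)cc2)cc1`) stands lowest of the three at 18.8% on these numbers. Compound 4 (`Nc1ccccc1NC(=O)c1ccc(CSCCc2ccccc2)cc1`) has phenethyl in place of 4-bromophenyl on a sulfur. The nearest evidence is a number 12 percentage points lower from compound 1 to compound 3 (beyond the scatter) and a number 15 percentage points lower from compound 2 to compound 3 (beyond the scatter) where bromo enters on an aromatic carbon. The step of a number 3 percentage points higher from compound 1 to compound 2 (within the scatter) shows little from the alkyl group. Within the data shown here, no measured compound replaces the whole group on sulfur, so this evidence is indirect. A small rise is expected, probably not beyond the scatter, as a number 6.2 percentage points higher from compound 3 to compound 4 (within the scatter) in estimate. For compound 4 the expected value is 25% (estimated range 10% to 42%).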

Compound 4, percent growth inhibition at one concentration: 27.7%
The estimate for compound 4 lay 2.7 percentage points below the measured number; the measured number falls inside the stated range.
By their numbers in this assay, from the lowest: compounds 3, 4, 1 and 2 (each within the scatter of the next, the first and the last beyond it).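

In this assay phenethyl on the sulfur stays within the scatter of all three aryl groups: 4-bromophenyl (a number 8.9 percentage points higher from compound 3 to compound 4 (within the scatter)), 4-methylphenyl (a number 6.1 percentage points lower from compound 2 to compound 4 (within the scatter)) and 4-ethylphenyl (a number 3.1 percentage points lower from compound 1 to compound 4 (within the scatter)). This position therefore accepts a ring held on a saturated chain, and compound 4 sorts with neither the bromo compound nor the alkyl compounds. No measurement here explains these steps. Open, from the compounds shown here alone, are a longer chain such as 3-phenylpropyl and a group on sulfur with no ring, such as a plain butyl chain. Also open, going by these compounds, is an amine or a carboxylic acid on the phenethyl ring.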